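The source may report more compounds than this note shows. Statements on the series, on what has been measured and on what is new or still open speak of the compounds shown alone.

Of the compounds shown here, three carrying the same core have been measured in a functional assay on HepG2 cells (Homo sapiens) for antiproliferative activity, read by MTT assay, with a stated time of 24 h; on this read-out higher numbers stand for weaker inhibition and lower numbers for stronger inhibition. Compound 1, `O=c1[nH]cc(S(=O)(=O)Nc2ccccc2-c2cn(-c3ccc(F)cc3)nn2)c(=O)[nH]1`, gives only a limit in this assay, > 20000 nM, and no number. Compound 2, `O=c1[nH]cc(S(=O)(=O)Nc2cccc(-c3cn(-c4ccccc4F)nn3)c2)c(=O)[nH]1`, gives 13900 nM in this assay. Compound 3, `O=c1[nH]cc(S(=O)(=O)Nc2ccc(-c3cn(-c4ccccc4)nn3)cc2)c(=O)[nH]1`, gives 18000 nM in this assay, the higher of the two numbers reported, though its gap to compound 2 lies within the usual scatter, so the two cannot be ranked against each other.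

Compound 4, `O=c1[nH]cc(S(=O)(=O)Nc2ccc(-c3cn(-c4cccc(F)c4)nn3)cc2)c(=O)[nH]1`, is not yet measured. It differs from compound 3 by fluoro in place of hydrogen on an aromatic carbon, on the aromatic ring attached to the triazole nitrogen, meta to a large group; read one bond further out, the change is phenyl to 3-fluorophenyl. Within the data shown here, no pair of measured compounds differs in a single place, so no measured step guides the expectation. Given that all three measured compounds sit at weak inhibition in this assay, the step from compound 3 to compound 4 is expected to be no change at the digits printed from compound 3 to compound 4 (within the scatter), no larger than the scatter and in no settled direction. Compound 4 is accordingly estimated at 18000 nM in this assay, with a plausible range from 8000 nM to 40000 nM.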

Compound 4, half-maximal inhibitory concentration: > 20000 nM
Compound 4 was reported as a limit; the forecaster's own chance of this, stated with the estimate: 40%; middle value at least 1.1-fold (0.04 log units) from the limit.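

Among these compounds, the change from phenyl to 3-fluorophenyl gives the first step between two compounds that differ in one place, and in this assay it reads as an at least 1.1-fold higher number from compound 3 to compound 4 (0.04 log units; that floor lies within the scatter). Compound 4 gives only a limit, > 20000 nM, so this step has a floor and no upper end, and that floor does not separate the two compounds. Fluoro on this aromatic carbon, meta to a large group, shows no stronger inhibition, and compound 4 stands at a limit shared within the series: the limit of > 20000 nM in this assay, at which 2 of the 4 values shown sit.

On these data alone, the true size of the step stays open, and so does whether it is a real change at all. Also open, as far as these compounds go, is whether an amine or a carboxylic acid in place of this fluoro would give a clearly lower number.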